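The compounds below may be only part of what the source reports. "The series", "measured", "known", "first", "only" and "open" are said of these compounds alone.

Measured compounds in the series:
Compound 1 `Cc1ccccc1-n1nncc1CN1C(=O)C2(C(C#N)=C(N)Oc3c2c2nc4ccccc4nc2c2ccccc32)c2ccccc21`: in a functional assay on HepG2 cells (Homo sapiens) for antiproliferative activity, read by MTT assay, with a stated time of 48 h (a higher number here means a weaker inhibitor, a lower number a stronger inhibitor), compound 1 gives > 50000 nM, which is a limit of the assay and not a number.
Compound 2 `CCOc1ccccc1-n1nncc1CN1C(=O)C2(C(C#N)=C(N)Oc3c2c2nc4ccccc4nc2c2ccccc32)c2ccccc21`: in this assay compound 2 gives > 50000 nM, again a limit.
Compound 3 `Cc1ccc(Cl)cc1-n1nncc1CN1C(=O)C2(C(C#N)=C(N)Oc3c2c2nc4ccccc4nc2c2ccccc32)c2ccccc21`: in this assay compound 3 gives > 50000 nM, again a limit.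

Compound 1 thus stands at a limit in this assay, and the two further values shown are limits as well; the series is summed up by the limit of > 50000 nM in this assay, at which 3 of the 3 values shown sit. The three steps among the measured compounds, a step that the two limits leave unreadable from compound 1 to compound 2, a step that the two limits leave unreadable from compound 1 to compound 3 and a step that the two limits leave unreadable from compound 2 to compound 3, are unreadable in both size and direction, and none of them separates one compound from another. Compound 4 `N#CC1=C(N)Oc2c(c3nc4ccccc4nc3c3ccccc23)C12C(=O)N(Cc1cnnn1-c1ccc(F)c(Cl)c1)c1ccccc12` differs from compound 1 as follows: 3-chloro-4-fluorophenyl in place of 2-methylphenyl on an aromatic nitrogen. The measured step that touches the same aromatic nitrogen, a step that the two limits leave unreadable from compound 2 to compound 3, gives no readable size, and the other two steps give none either, so no step beyond the scatter can be expected in either direction; the most that the data support is the expectation that compound 4 also sits at the limit. Compound 4 is therefore estimated at 70000 nM in this assay, with a range from 25000 nM to 200000 nM, which is expected to mean a step that the limit leaves unreadable from compound 1 to compound 4.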

Compound 4, half-maximal inhibitory concentration: > 50000 nM
Compound 4 was reported as a limit (the forecaster's own chance of this, stated with the estimate: 80%); the middle value does not contradict the limit.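

In this assay compound 4 gives > 50000 nM, a limit and not a number. Its steps from compound 1, compound 2 and compound 3 cannot be read in size or direction. The series rests at one limit: the limit of > 50000 nM in this assay, at which 4 of the 4 values shown sit.

The compounds shown leave open whether any phenyl group on this aromatic nitrogen gives a readable number in this assay.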